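Swapping an Amide Chain for a Cyclopentyl Imidazole

A few compounds are considered here, and "the series" means these few. Any claim that something is new, unique, unknown or untested is made for them only; others in the source may bear on it.

Compound 1 `Cc1nn(-c2ccc3ncccc3c2)c2nc(Nc3cnn(C4CCNCC4)c3)ncc12` inhibits the target in an assay on isolated protein for inhibition of eIF-2-alpha kinase GCN2 (Homo sapiens) (on this read-out lower numbers stand for stronger inhibition and higher numbers for weaker inhibition), with 11 nM. Compound 2 `COCCNC(=O)CCNc1ncc2c(Br)nn(-c3ccc4ncccc4c3)c2n1` sits at > 1000 nM, which is a limit of the assay rather than a measured number (the limit of > 1000 nM in this assay, at which 1 of the 2 values shown sits). Compound 3 `Brc1nn(-c2ccc3ncccc3c2)c2nc(N[C@@H]3CC[C@@H](c4ncc[nH]4)C3)ncc12` differs from compound 2 by a group of 10 heavy atoms (8 carbon, 2 nitrogen; one five-membered non-aromatic ring of carbon only, one five-membered aromatic ring with 2 hetero atoms) in place of a group of 9 heavy atoms (6 carbon, 1 nitrogen, 2 oxygen; no ring), on a nitrogen on an aromatic ring. This gives a ring-bearing amine like that of compound 1, which shows 11 nM. The change is expected to bring a gain well beyond the usual scatter an at least 20-fold lower number from compound 2 to compound 3 (1.30 log units; beyond the scatter). Compound 3 is therefore estimated at 50 nM, between 8 nM and 400 nM.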

Compound 3, half-maximal inhibitory concentration: 21 nM
For compound 3 the middle estimate is 2.4-fold (0.38 log units) above the measured one; the range from low to high includes it.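

On a nitrogen on an aromatic ring, replacing the 2-((2-methoxyethyl)carbamoyl)ethyl chain with the group carrying a five-membered carbon ring and a five-membered aromatic ring gives, in this assay, an at least 47-fold lower number from compound 2 to compound 3 (1.67 log units; beyond the scatter). This single change, with the rest of the molecule the same, shows that this position strongly affects the read-out. The full size of the step stays unknown, as compound 2 stands at a limit of the assay: the limit of > 1000 nM in this assay, at which 1 of the 3 values shown sits.

The compounds shown do not separate the contribution of the carbon ring from that of the aromatic ring. A plain cyclopentyl amine, or a carboxylic acid in place of the imidazole, would address that question.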